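A few compounds are considered here, and "the series" means these few. Any claim that something is new, unique, unknown or untested is made for them only; others in the source may bear on it.

Compound 1, `N#Cc1cc2c(nc1N1CCC(C(=O)NS(=O)(=O)C(F)(F)c3ccccc3)CC1)COC2=O`, has no number in a functional assay (Platelet, plasma) for inhibition, with Homo sapiens as the target; a higher number here means a weaker inhibitor, a lower number a stronger inhibitor: in this assay compound 1 stands at "not determined" (no result reported). Compound 2, `CC1OC(=O)c2cc(C#N)c(N3CC(C(=O)NS(=O)(=O)Cc4ccccc4)C3)nc21`, gives in this assay only a limit of the assay, > 300000 nM. Of the values shown, one sits at such a limit (the limit of > 300000 nM in this assay, at which 1 of the 2 values shown sits). Compound 3, `N#Cc1cc2c(nc1N1CCC(C(=O)NS(=O)(=O)Cc3ccc(F)cc3F)CC1)COC2=O`, differs from compound 1 by 2,4-difluorobenzyl in place of difluoro(phenyl)methyl on a sulfonyl sulfur. No measured step in this assay exists between these compounds, so the direction of the change from compound 1 to compound 3 cannot be read from any shown value. Compound 3 is expected to give about 100000 nM in this assay, estimated within 5000 nM to 300000 nM.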

Compound 3, half-maximal inhibitory concentration: 5200 nM
For compound 3 the middle estimate is 19-fold (1.28 log units) above the measured one; the range from low to high includes it.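

In this assay no new step can be read for compound 3: neither compound 1 nor compound 2 offers a number to set against it. As far as these compounds go, how the difluoro(phenyl)methyl and 2,4-difluorobenzyl groups compare on the sulfonyl sulfur remains open.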